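The source may report more compounds than this note shows. Statements on the series, on what has been measured and on what is new or still open speak of the compounds shown alone.

Values in an ADME assay on HaCaT cells (Homo sapiens) for cytotoxicity, read by MTT assay, with a stated time of 48 h; a higher number here means a weaker inhibitor, a lower number a stronger inhibitor:
- Compound 1 `Fc1ccc(-c2nn(-c3ccccc3)cc2-c2nc3cc(Cl)ccc3[nH]2)cc1`: > 50000 nM, a limit.
- Compound 2 `Fc1ccc(-c2nn(-c3ccccc3)cc2-c2nc3cc(C(F)(F)F)ccc3[nH]2)cc1`: > 50000 nM, a limit.
- Compound 3 `O=C(OCc1ccccc1)c1ccc2[nH]c(-c3cn(-c4ccccc4)nc3-c3ccc(F)cc3)nc2c1`: > 50000 nM, a limit.

The whole set stands at the limit of > 50000 nM in this assay, at which 3 of the 3 values shown sit. Compound 3 therefore has no number, and nothing places it relative to the other two.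

Compound 4 `O=C(OCc1ccccc1)c1ccc2[nH]c(-c3cn(-c4ccccc4)nc3-c3ccc(Cl)cc3)nc2c1` differs from compound 3 by chloro in place of fluoro on an aromatic carbon, that is, 4-fluorophenyl to 4-chlorophenyl. Among the measured compounds shown here, no measured step covers this change. For the measured compounds named here, the only steps available are exchanges at another place: a step that the two limits leave unreadable from compound 1 to compound 2, a step that the two limits leave unreadable from compound 1 to compound 3 and a step that the two limits leave unreadable from compound 2 to compound 3. None of them has a readable size, so no size carries over, and all three groups stay at the limit.

No step beyond the scatter is expected in this assay, and no direction can be assigned. The expectation rests on compound 3, whose > 50000 nM is a limit. The expected change is a step that the limit leaves unreadable from compound 3 to compound 4. The estimate for compound 4 is 60000 nM, with an expected range of 30000 nM to 120000 nM.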

Compound 4, half-maximal inhibitory concentration: > 50000 nM
Compound 4 ended at the assay's limit; the forecaster's own chance of this, stated with the estimate: 85%; the middle value does not contradict the limit.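

No new step can be read from compound 3 to compound 4, since both stand at a limit in this assay: the limit of > 50000 nM in this assay, at which 4 of the 4 values shown sit. The compounds shown leave open how far any of them lies from that limit, and whether any change on the shared core gives a measurable value.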